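The source may hold more compounds than are shown below. What is called first, only, known or untested is meant among the compounds shown, and "the series" means these compounds.

Measured so far:
compound 1, `C=C1C[C@H](O)[C@@H]2[C@](C)(CCC[C@]2(C)C(=O)O[C@@H]2O[C@H](CO)[C@@H](O)[C@H](O)[C@H]2O)[C@H]1CCC1=CCOC1=O` — 35700 nM in a functional assay on BV-2 cells (Mus musculus) for inhibition, read by Griess assay, with a stated time of 24 h; on this read-out lower numbers stand for stronger inhibition and higher numbers for weaker inhibition
compound 2, `C=C1CC[C@@H]2[C@](C)(CCC[C@]2(C)C(=O)O[C@@H]2O[C@H](CO)[C@@H](O)[C@H](O)[C@H]2O)[C@H]1CC/C(=C\CO)CO` — 65400 nM in this assay

Compound 2 carries the highest of the two numbers; its nearest neighbour is compound 1, whose number is lower by a margin that falls within the scatter of this assay, so the two values cannot be ordered. Compound 1 differs from compound 2 in more than one place, so it is not a single step.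

Compound 3, `C=C1CC[C@@H]2[C@](C)(CCC[C@]2(C)C(=O)O[C@@H]2O[C@H](CO)[C@@H](O)[C@H](O)[C@H]2O)[C@H]1CCC1=CC(=O)OC1`, has not yet been measured in this assay. It differs from compound 2 by a single change, (a group of 6 heavy atoms (4 carbon, 2 oxygen; one five-membered non-aromatic ring with 1 hetero atom) in place of a group of 6 heavy atoms (4 carbon, 2 oxygen; no ring), on a saturated chain carbon, two bonds along the chain from a saturated ring carbon). Within the data shown here, no step between measured compounds shows the effect of this change on its own; compound 1 carries the same kind of five-membered ring together with a further difference, and its value sits within the scatter of compound 2. He therefore expects the step from compound 2 to compound 3, a 1.6-fold lower number from compound 2 to compound 3 (0.19 log units; within the scatter), to be small and not beyond the scatter, with a slight lean toward a lower number. For compound 3 he estimates 42000 nM, in the range 15000 nM to 110000 nM.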

Compound 3, half-maximal inhibitory concentration: 54100 nM
Beside the measured number, compound 3's estimate is 1.3-fold (0.11 log units) below it; the measured number falls inside the stated range.
By their numbers in this assay, from the lowest: compounds 1, 3 and 2 (each within the scatter of the next).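

With compound 1 the five-membered ring came together with a further difference, whereas in this assay the change can now be read on its own at this position, on a saturated chain carbon, two bonds along the chain from a saturated ring carbon: a 1.2-fold lower number from compound 2 to compound 3 (0.08 log units; within the scatter). Within the scatter, then, this assay does not separate the open group, with no ring and 2 hydrogen-bond donors, from the group with one five-membered non-aromatic ring and 0 hydrogen-bond donors, although both groups have 6 heavy atoms and 2 hydrogen-bond acceptors. Nothing available bears on an explanation of this result.

The compounds shown leave open whether an amine, a carboxylic acid or a longer chain at this same position would give a step beyond the scatter. Among these compounds, they also leave open what the further difference carried by compound 1 does on its own, as no single step isolates it.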